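The compounds below may be only part of what the source reports. "The series", "measured", "known", "first", "only" and "open" are said of these compounds alone.

Going by the values given here, in an assay on HEK293 cells for positive allosteric modulation of metabotropic glutamate receptor 2 (Rattus norvegicus), read by thallium flux (on this read-out higher numbers stand for an effect only at larger amounts of compound and lower numbers for an effect already at smaller amounts), compound 2 `O=C(O)c1cc(F)cc(-c2cccc(COc3ccc4c(c3)CN(C3CCCC3)C4=O)c2)c1` gives 130 nM, while compound 1 `COc1ccc(C(=O)O)cc1-c1cccc(COc2ccc3c(c2)CN(C2CCCC2)C3=O)c1` gives 80 nM; the single measured step, a 1.6-fold higher number from compound 1 to compound 2 (0.21 log units; within the scatter), stays within the scatter, so the two compounds stand level on the numbers at hand. Compound 3 `Cc1ccc(C(=O)O)cc1-c1cccc(COc2ccc3c(c2)CN(C2CCCC2)C3=O)c1` differs from compound 2 by 5-carboxy-2-methylphenyl in place of 3-carboxy-5-fluorophenyl on an aromatic carbon. Among the compounds with values here, this returns an aryl group closely resembling that of compound 1, and the one step that bears on it was small, so no movement beyond the scatter is expected in this assay. Compound 3 is therefore estimated at 85 nM (range 35 nM to 200 nM). The expected step is a 1.5-fold lower number from compound 2 to compound 3 (0.18 log units; within the scatter).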

Compound 3, half-maximal effective concentration: 110 nM
Compound 3: middle estimate off by 1.3-fold (0.11 log units), on the low side; low and high end bracket the measured number.
By their numbers in this assay, from the lowest: compounds 1, 3 and 2 (each within the scatter of the next).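

In this assay the change to 5-carboxy-2-methylphenyl brings a 1.2-fold lower number from compound 2 to compound 3 (0.07 log units; within the scatter) and methyl in place of methoxy brings a 1.4-fold higher number from compound 1 to compound 3 (0.14 log units; within the scatter) on the same aryl group. Both steps stay within the scatter, so this position accepts all three aryl groups, including a methyl and a methoxy variant, without a readable difference. Nothing on hand gives a reason for this. Going by these compounds, whether chloro or ethyl in place of methyl would move the number beyond the scatter stays open. So does the effect of a tetrazole or a primary amide in place of the carboxylic acid.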